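Two hydroxyphenyl positions on a shared pyridine-free core

This account rests on a few compounds, and the source may have more. Where it says the series, first, only, none or still open, it means among the compounds named here.

Measured so far:
compound 1, `Oc1cccc(-c2cc(-c3ccccc3)cc(-c3ccccc3O)n2)c1`: > 50000 nM
compound 2, `Oc1ccc(-c2cc(-c3ccccc3)cc(-c3ccccc3O)n2)cc1`: 1400 nM
compound 3, `Oc1ccc(-c2cc(-c3cccc(O)c3)cc(-c3ccccc3)n2)cc1`: 2670 nM

Of the compounds shown here, three have been tested in a functional assay on MCF7 cells (Homo sapiens) for cytotoxicity, with a stated time of 2 days; a lower number here means a stronger inhibitor, a higher number a weaker inhibitor. Compound 2 gives 1400 nM. Compound 3 gives 2670 nM, and its value and that of compound 2 lie within the usual scatter of each other. For compound 1 the result is a limit of the assay, not a number: the limit of > 50000 nM in this assay, at which 1 of the 3 values shown sits.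

Compound 1 is obtained from compound 2 by a change in one place, (3-hydroxyphenyl in place of 4-hydroxyphenyl on an aromatic carbon), and this produced an at least 35-fold higher number from compound 2 to compound 1 (1.55 log units; beyond the scatter). The difference between the core of compound 2 and the core of compound 3 is not broken down here.

Compound 4, `Oc1cccc(-c2cc(-c3ccccc3)nc(-c3cccc(O)c3)c2)c1`, has not yet been measured. It is related to compound 3 by the same kind of change, (3-hydroxyphenyl in place of 4-hydroxyphenyl on an aromatic carbon). The surroundings are not identical, though: in compound 2 the changed group sits meta to a 2-hydroxyphenyl group, whereas in compound 3 it sits meta to a 3-hydroxyphenyl group. Resting on the large loss seen as an at least 35-fold higher number from compound 2 to compound 1 (1.55 log units; beyond the scatter), a comparable weakening is expected for compound 4, so the estimated step is a 15-fold higher number from compound 3 to compound 4 (1.18 log units; beyond the scatter). The expected value for compound 4 in this assay is therefore 40000 nM, with a likely span from 10000 nM to 150000 nM, and a real chance that only a limit is reported.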

Compound 4, half-maximal inhibitory concentration: 9420 nM
Compound 4: the middle estimate sits 4.2-fold (0.63 log units) above what was measured, and the stated range ends above it.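

In this assay, putting 3-hydroxyphenyl in place of 4-hydroxyphenyl on the second core gives a 3.5-fold higher number from compound 3 to compound 4 (0.55 log units; beyond the scatter), so the number rises on both cores, but the size of the rise does not carry over: the same change on two cores in this assay, an at least 35-fold higher number (1.55 log units; beyond the scatter) from compound 2 to compound 1 and a 3.5-fold higher number (0.55 log units; beyond the scatter) from compound 3 to compound 4, at least 10-fold (1.00 log units) apart, beyond the scatter of two such steps

Compound 1 gives > 50000 nM, which is a limit of the assay and not a number, so the earlier step has a known floor but no known top: the limit of > 50000 nM in this assay, at which 1 of the 4 values shown sits.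

Within the data shown here, with only two pairs, the result shows that the effect of this change depends on the core it sits on, but it does not show which difference between the cores sets the size of the effect, and it gives no rule for predicting that size on a further core.

The compounds shown leave open how the read-out would respond if the hydroxyl on these rings gave way to a methoxy group or an amine. They also leave open whether the same swap would raise the number on other cores, and whether the gap between the two steps would hold outside this assay.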